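This account rests on a few compounds, and the source may have more. Where it says the series, first, only, none or still open, it means among the compounds named here.

Measured in a functional assay on NCI-H460 cells (Homo sapiens) for cytotoxicity, read by MTT assay, with a stated time of 68 h; on this read-out lower numbers stand for stronger inhibition and higher numbers for weaker inhibition:
- compound 1 `COc1ccc(-c2cc(NC(=O)C(Cl)Cl)cc(-c3ccc(OC)c(F)c3)c2)cc1F`: 1760 nM
- compound 2 `Nc1cccc(-c2cccc(NC(=O)C(Cl)Cl)c2)c1`: > 50000 nM

Compound 2 gives no number in this assay, and its > 50000 nM is a limit of the assay. Among the measured compounds shown here, that leaves compound 1, at 1760 nM, as the only compound in this set with a measured number.

Compound 3 `Cc1cccc(-c2cccc(NC(=O)C(Cl)Cl)c2)c1` carries methyl in place of amino on an aromatic carbon, meta to a large group (methyl in place of amino on an aromatic carbon). For the measured compounds named here, no measured step covers this change, so any expectation is loose. A modest move towards stronger inhibition in this assay is expected, with compound 3 still not expected to reach the level of compound 1 at 1760 nM. The expected step is an at least 2.0-fold lower number from compound 2 to compound 3 (0.30 log units; that floor lies within the scatter), and a further limit remains a real possibility. For compound 3 the estimated value is 25000 nM, with an expected range of 8000 nM to 50000 nM.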

Compound 3, half-maximal inhibitory concentration: 24300 nM
For compound 3 the middle estimate is 1.0-fold (0.01 log units) above the measured one; the range from low to high includes it.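

In this assay, methyl in place of amino on an aromatic carbon, meta to a large group, gives an at least 2.0-fold lower number from compound 2 to compound 3 (0.31 log units; beyond the scatter), so this position responds to the group it carries. With methyl there, the position yields a measured number, with compound 3 at 24300 nM. The full size of the step stays unknown, because the entry for compound 2 is a limit and not a number: the limit of > 50000 nM in this assay, at which 1 of the 3 values shown sits.

The compounds shown do not tell whether the change in this assay comes with methyl itself or with the loss of amino; a hydroxyl group or a chlorine atom at the same place would separate the two. On these data alone, how compound 3 relates to compound 1 also stays open, since the two differ in more than one place.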